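A few compounds are considered here, and "the series" means these few. Any claim that something is new, unique, unknown or untested is made for them only; others in the source may bear on it.

Measured so far:
compound 1, `COc1cc2c(Nc3ccc(C#N)cc3)ncnc2cc1OCCCN1CCC(C)CC1`: 32300 nM
compound 2, `COc1cc2c(Nc3ccc(C#N)cc3)ncnc2cc1OCCCN1CCC(O)CC1`: 29900 nM

In a functional assay on A549 cells (Homo sapiens) for antiproliferative activity, read by MTT assay, with a stated time of 72 h (on this read-out lower numbers stand for stronger inhibition and higher numbers for weaker inhibition), compound 1 gives 32300 nM, and in this assay compound 2 gives 29900 nM. For the measured compounds named here, the two numbers sit within the scatter of each other, as the step of a 1.1-fold lower number from compound 1 to compound 2 (0.03 log units; within the scatter) shows; on the numbers so far compound 2 cannot be told apart from compound 1.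

Compound 3, `COc1cc2c(Nc3ccc(C#N)cc3)ncnc2cc1OCCCN1CCc2ccccc2C1`, is not yet measured. It differs from compound 2 by 1,2,3,4-tetrahydroisoquinolin-2-yl in place of 4-hydroxypiperidin-1-yl on a saturated chain carbon, three bonds along the chain from an oxygen on an aromatic ring. Going by the values given here, the only measured step, a 1.1-fold lower number from compound 1 to compound 2 (0.03 log units; within the scatter), changes a substituent on the saturated ring and leaves the ring itself in place, so it bears on the new change only loosely. Among the compounds with values here, no measured pair shows what happens when the saturated ring is exchanged for a fused bicyclic group. With that weak support, the step of a 1.2-fold lower number from compound 2 to compound 3 (0.08 log units; within the scatter) is expected to stay small in either direction. Compound 3 is estimated at 25000 nM, with a range from 7000 nM to 90000 nM.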

Compound 3, half-maximal inhibitory concentration: > 100000 nM
Compound 3: a limit, no number; the forecaster's own chance of this, stated with the estimate: 10%; middle value at least 4.0-fold (0.60 log units) away from the limit.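

In this assay compound 3 gives a limit of the assay and not a number: the limit of > 100000 nM in this assay, at which 1 of the 3 values shown sits. It shows that the group on this saturated chain carbon, three bonds along the chain from an oxygen on an aromatic ring, can move the number beyond the scatter: 1,2,3,4-tetrahydroisoquinolin-2-yl in place of 4-hydroxypiperidin-1-yl gives an at least 3.3-fold higher number from compound 2 to compound 3 (0.52 log units; beyond the scatter), and in place of 4-methylpiperidin-1-yl it gives an at least 3.0-fold higher number from compound 1 to compound 3 (0.49 log units; beyond the scatter). The earlier change of a ring substituent alone had stayed within the scatter, so exchanging the whole group matters here in a way that change did not show.

As far as these compounds go, the full size of both new steps stays open, as compound 3 has only a limit. Also open, from the compounds shown here alone, is whether a morpholin-4-yl or dimethylamino group here, or a longer chain, would read like compound 2 or like compound 3.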